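Next halogen in the series: outlook for compound 4

The source may hold more compounds than are shown below. What is called first, only, known or untested is meant among the compounds shown, and "the series" means these compounds.

Among the measured compounds shown here, in a functional assay on MDA-MB-468 cells (Homo sapiens) for antiproliferative activity (a higher number here means a weaker inhibitor of growth, a lower number a stronger inhibitor of growth), three compounds sharing one core have numbers so far. Compound 1 `COc1ccc(-c2nc3cc(F)ccc3s2)cc1C`, which carries methyl, gives 58 nM. Compound 2 `COc1ccc(-c2nc3cc(F)ccc3s2)cc1F`, which carries fluoro, gives 640 nM. Compound 3 `COc1ccc(-c2nc3cc(F)ccc3s2)cc1Cl`, which carries chloro, gives 480 nM. Compound 3 therefore stands level with compound 2 within the scatter, and both are clearly weaker than compound 1.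

Compound 4 `COc1ccc(-c2nc3cc(F)ccc3s2)cc1I` is the next change from compound 3: iodo in place of chloro on an aromatic carbon. The swap is iodo in place of chloro on an aromatic carbon, ortho to a methoxy group.

For the measured compounds named here, three measured steps bear on it. Replacing methyl with a halogen gave an 11-fold higher number from compound 1 to compound 2 (1.04 log units; beyond the scatter) and an 8.3-fold higher number from compound 1 to compound 3 (0.92 log units; beyond the scatter). Going by the values given here, the only swap of one halogen for another gave a 1.3-fold lower number from compound 2 to compound 3 (0.12 log units; within the scatter), which is the closest precedent and lies within the scatter. Among the compounds with values here, no iodo compound has a number yet, so this single precedent is thin, and a drift towards compound 1 cannot be excluded. In this assay, only a small step is therefore expected, leaning slightly towards a lower number. The expected step is a 1.6-fold lower number from compound 3 to compound 4 (0.20 log units; within the scatter). Compound 4 is estimated at 300 nM, with an expected range from 80 nM to 1000 nM.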

Compound 4, concentration for 50% growth inhibition: 360 nM
The estimate for compound 4 lay 1.2-fold (0.08 log units) below the measured number, within the range that was stated.
By their numbers in this assay, from the lowest: compound 1; then compounds 4, 3 and 2 (each within the scatter of the next).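

In this assay, iodo on this aromatic carbon, ortho to a methoxy group, extends the halogen set, and it shows no separation from the other two halogens: the record gives a 1.3-fold lower number from compound 3 to compound 4 (0.12 log units; within the scatter) and also a 1.8-fold lower number from compound 2 to compound 4 (0.25 log units; within the scatter), both within the scatter. Fluoro, chloro and iodo therefore sit at one level at this position, while methyl stays apart, with a 6.2-fold higher number from compound 1 to compound 4 (0.79 log units; beyond the scatter) beyond the scatter, like the steps from compound 1 to compound 2 and compound 3. Among these four compounds, then, the change that matters at this position is methyl against any halogen, not one halogen against another, and no measurement shown here accounts for that gap.

From the compounds shown here alone, whether the level of compound 1 belongs to methyl alone or extends to other carbon groups stays open, and an ethyl group, a trifluoromethyl group or a longer chain on this carbon would test it. An amine or a carboxylic acid at the same place is equally untested in these data, and the level shared by the halogens is known only with the rest of the shared core unchanged.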